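Chloro for Ethoxy on the Outer Ring

The source may hold more compounds than are shown below. What is called first, only, known or untested is meant among the compounds shown, and "the series" means these compounds.

Of the compounds shown here, two have been measured in an assay on isolated protein with Bile acid receptor (Homo sapiens) as the target; a higher number here means that more compound is needed for the effect, a lower number that less compound is needed. Compound 1 `COC(=O)/C=C/c1cccc(N(Cc2ccc(/C=C/c3ccccn3)cc2)C(=O)C2CCCCC2)c1` gives 309 nM. Going by the values given here, compound 2 `CCOc1cccc(-c2ccc(CN(C(=O)C3CCCCC3)c3cccc(/C=C/C(=O)OC)c3)cc2)c1` gives 147 nM, the lower of the two numbers; the single measured step, a 2.1-fold lower number from compound 1 to compound 2 (0.32 log units; beyond the scatter), separates them, and that step swaps a whole group on the outer ring for another. Compound 3 `COC(=O)/C=C/c1cccc(N(Cc2ccc(-c3cccc(Cl)c3)cc2)C(=O)C2CCCCC2)c1` has not yet been measured in this assay. It differs from compound 2 in one place: chloro in place of ethoxy on an aromatic carbon. Among the compounds with values here, no measured step bears on this change, since the one known step exchanges a different group entirely and offers no guide to trading ethoxy for chloro on the same ring. With nothing to point either way, the expected step for compound 3 is a 1.0-fold higher number from compound 2 to compound 3 (0.01 log units; within the scatter), a change no larger than the usual scatter. Compound 3 is therefore estimated at 150 nM, with a range from 55 nM to 400 nM.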

Compound 3, half-maximal effective concentration: 94 nM
The estimate for compound 3 lay 1.6-fold (0.20 log units) above the measured number; measured number inside the range.
By their numbers in this assay, from the lowest: compounds 3 and 2 (each within the scatter of the next); then compound 1.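

With chloro in place of ethoxy, a 1.6-fold lower number from compound 2 to compound 3 (0.19 log units; within the scatter) is what this assay records, so at this position on the outer ring three heavy atoms and a hydrogen-bond acceptor can be replaced by one chlorine atom without a change that can be told from scatter. Set against the 2-(pyridin-2-yl)ethenyl group, the 3-chlorophenyl group gives a 3.3-fold lower number from compound 1 to compound 3 (0.52 log units; beyond the scatter) and this step, unlike the one from ethoxy to chloro, is a real if modest difference. No measurement here explains why either step has the size it does.

From the compounds shown here alone, it remains open whether a fluoro, an amine or a carboxylic acid on the same aromatic carbon would keep the number in this range. Going by these compounds, it is also open whether the outer ring needs any group at this position at all.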